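The source may report more compounds than this note shows. Statements on the series, on what has been measured and on what is new or still open speak of the compounds shown alone.

Working notes on the series. In a functional assay on MDA-MB-231 cells (Homo sapiens), read by wound healing assay, with a stated time of 24 h (a lower number here means a stronger inhibitor, a higher number a weaker inhibitor), compound 1 `CC(=O)O[C@H]1CC[C@]2(C)[C@H](CC[C@@](C)(O)[C@H]2CC[C@@H]2C(C)=CC[C@H]3[C@H](CC[C@]3(C)O)C2(C)C)OC1(C)C` gives 16800 nM as the starting point for this comparison. In this assay compound 2 `CC1=CC[C@H]2[C@H](CC[C@]2(C)O)C(C)(C)[C@@H]1CC[C@H]1[C@]2(C)CC[C@H](OC(=O)c3ccncc3)C(C)(C)O[C@H]2CC[C@@]1(C)O` gives 10600 nM; 10600 nM (2 entries) and compound 3 `CC1=CC[C@H]2[C@H](CC[C@]2(C)O)C(C)(C)[C@@H]1CC[C@H]1[C@]2(C)CC[C@H](OC(=O)c3ccc(Cl)cc3)C(C)(C)O[C@H]2CC[C@@]1(C)O` gives 5300 nM; 5300 nM (2 entries) on the same read-out. Compound 1 lies within the usual scatter of compound 2 but is separated from compound 3 by more than that scatter, with compound 3 the stronger of that pair. Compound 2 lies within the scatter of both.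

Among the measured compounds shown here, compound 4 `CC1=CC[C@H]2[C@H](CC[C@]2(C)O)C(C)(C)[C@@H]1CC[C@H]1[C@]2(C)CC[C@H](OC(=O)NS(=O)(=O)c3ccc(C)cc3)C(C)(C)O[C@H]2CC[C@@]1(C)O` has no measurement yet. The change from compound 1 to compound 4 is ((4-methylphenyl)sulfonyl)amino in place of methyl on a carbonyl carbon and puts ((4-methylphenyl)sulfonyl)amino in place of methyl on a carbonyl carbon. For the measured compounds named here, no measured pair isolates this replacement, so the expectation is indirect. Compound 2 at 10600 nM; 10600 nM (2 entries) and compound 3 at 5300 nM; 5300 nM (2 entries) also carry an aromatic ring in place of that methyl, and neither value is higher than that of compound 1. A modest move toward a lower number in this assay is therefore expected, near the edge of the scatter. The expected change is a 2.1-fold lower number from compound 1 to compound 4 (0.32 log units; beyond the scatter) and could still prove indistinguishable from no change. For compound 4 the estimated value is 8000 nM with an expected range of 3000 nM to 20000 nM in this measurement.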

Compound 4, half-maximal inhibitory concentration: 18000 nM
Estimate against measurement, compound 4: 2.3-fold (0.35 log units) below; low and high end bracket the measured number.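

In this assay the change gives a 1.1-fold higher number from compound 1 to compound 4 (0.03 log units; within the scatter), so at this position ((4-methylphenyl)sulfonyl)amino can take the place of methyl on a carbonyl carbon with no readable shift, despite the much larger group entering. An aromatic ring in the group on this carbonyl carbon therefore does not by itself go with a lower number: compound 3 gives 5300 nM; 5300 nM (2 entries), whereas compound 4, which also carries such a ring, gives 18000 nM. Nothing available explains this outcome or accounts for the difference between the printed values of these two compounds.

The compounds shown do not separate the contribution of the sulfonylamino link from that of the ring it carries, and a 4-methylphenyl group placed directly on the carbonyl carbon, or a phenylamino group, would divide the two. On these data alone, it also remains open how this position responds to a group with no aromatic ring larger than methyl, such as a longer alkyl chain or a dimethylamino group, and whether the ester is needed at all, which a free hydroxyl in its place would test.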